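A few compounds are considered here, and "the series" means these few. Any claim that something is new, unique, unknown or untested is made for them only; others in the source may bear on it.

Compound 3 `CCC1(CCCCN2CCN(c3cccc(Cl)c3)CC2)C(=O)Nc2ccccc21` in a functional assay on the whole organism (strain Wistar) with Rattus norvegicus as the target, with a stated time of 5 min (on this read-out lower numbers stand for an effect already at smaller amounts and higher numbers for an effect only at larger amounts of compound), gives > 20 mg/kg, which is a limit of the assay and not a number. Compound 1 `CCC1(CCCCN2CCN(c3cccc(Cl)c3)CC2)C(=O)Nc2cc(F)ccc21` gives > 20 mg/kg, likewise a limit. Compound 2 `CC(C)CC1(CCCCN2CCN(c3cccc(Cl)c3)CC2)C(=O)Nc2ccccc21` gives 10 mg/kg. The step that the two limits leave unreadable from compound 1 to compound 3 is left unreadable by the two limits, and the step of an at least 2.0-fold higher number from compound 2 to compound 3 (0.30 log units; that floor lies within the scatter) has a floor that lies within the scatter. Going by the values given here, compound 3 therefore stands at the limit of > 20 mg/kg in this assay, at which 2 of the 3 values shown sit, with no measured step that places it beyond the scatter of any other compound.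

Compound 4 `CCC1(CCCCN2CCN(c3ccc(Cl)c(Cl)c3)CC2)C(=O)Nc2ccccc21` differs from compound 3 by chloro in place of hydrogen on an aromatic carbon, a change that reads as 3-chlorophenyl to 3,4-dichlorophenyl. Among the compounds with values here, no measured step touches the aromatic ring carrying the chloro group: the readable step concerns the saturated chain, the other is unreadable. Nothing in the series therefore points in either direction for this change. The step is expected to be a number no higher from compound 3 to compound 4 (the limit leaves the size open). Compound 4 is estimated at 20 mg/kg, ranging from 8 mg/kg to 50 mg/kg, most likely reported again as a limit.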

Compound 4, minimum effective dose: > 20 mg/kg
Compound 4 was reported as a limit (the forecaster's own chance of this, stated with the estimate: 65%); the middle value sits exactly at the limit.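

No step can be read between compound 3 and compound 4, as neither value is a number but a limit of the assay: the limit of > 20 mg/kg in this assay, at which 3 of the 4 values shown sit.

The compounds shown leave open both the direction and the size of any change from 3-chlorophenyl to 3,4-dichlorophenyl.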